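The source may report more compounds than this note shows. Statements on the series, on what has been measured and on what is new or still open speak of the compounds shown alone.

Of the compounds shown here, three have been read in an in vitro ADME assay on microsomes from liver (Rattus norvegicus) for metabolic stability; on this read-out lower numbers stand for slow clearance and higher numbers for fast clearance. Compound 1 `CC(C)NC(=O)[C@H]1CC[C@@H](n2/c(=N/C(=O)c3ccc(C#N)c(F)c3)[nH]c3ccc(CN4CCC(C(C)(C)O)CC4)cc32)CC1` gives 29 mL.min-1.g-1, compound 2 `CC(C)NC(=O)[C@H]1CC[C@@H](n2/c(=N/C(=O)c3ccc(F)cc3)[nH]c3ccc(CN4CCC[C@H]4C(C)(C)O)cc32)CC1` gives 455 mL.min-1.g-1 and compound 3 `CCNC(=O)[C@H]1CC[C@@H](n2/c(=N/C(=O)c3ccccc3)[nH]c3ccc(CN4CCCCC4)cc32)CC1` gives 310 mL.min-1.g-1. Compound 2 stands at the high end of these numbers together with compound 3, the two lying within the scatter of each other, while the gap to compound 1 is well beyond the scatter.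

Compound 4 `CC(C)NC(=O)[C@H]1CC[C@@H](n2/c(=N/C(=O)c3ccc(F)cc3)[nH]c3ccc(CNCC(C)(C)O)cc32)CC1` is the next to be read. It departs from compound 2 by (2-hydroxy-2-methylpropyl)amino in place of 2-(1-hydroxy-1-methylethyl)pyrrolidin-1-yl on a saturated chain carbon bound to an aromatic carbon. Among the measured compounds shown here, no measured pair differs in one place only, so no measured step guides this change. Compound 1 at 29 mL.min-1.g-1 shows that low numbers occur in the series, but it differs from compound 2 in more than one place. A moderate fall in this assay is expected, and a result within the scatter cannot be excluded. The expected change is a 2.7-fold lower number from compound 2 to compound 4 (0.43 log units; beyond the scatter). For compound 4 the estimate is 170 mL.min-1.g-1, with an expected range of 50 mL.min-1.g-1 to 450 mL.min-1.g-1.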

Compound 4, intrinsic clearance in microsomes: 68 mL.min-1.g-1
Compound 4: middle estimate off by 2.5-fold (0.40 log units), on the high side, within the range that was stated.
By their numbers in this assay, from the lowest: compound 1; then compound 4; then compounds 3 and 2 (each within the scatter of the next).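

Read in this assay this position gives a 6.7-fold lower number from compound 2 to compound 4 (0.83 log units; beyond the scatter) and so is shown for the first time to move the read-out with the rest of the molecule held constant. Among the compounds shown here, the single step joins several differences: 2-(1-hydroxy-1-methylethyl)pyrrolidin-1-yl leaves and (2-hydroxy-2-methylpropyl)amino enters, with fewer heavy atoms, no ring, no defined stereocentre and one more hydrogen-bond donor. Nothing at hand bears on why the number falls.

The compounds shown do not separate the loss of the ring from the gain of the donor, and a (2-methoxy-2-methylpropyl)amino chain or an unsubstituted pyrrolidin-1-yl at the same place would bear on that. Also open, on these data alone, is whether the step holds with other groups elsewhere on the shared core.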